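Chloro on Two Cores in a Cytotoxicity Assay

The source may report more compounds than this note shows. Statements on the series, on what has been measured and on what is new or still open speak of the compounds shown alone.

The measured compounds and their values:
compound 1, `C/C(=N\NC(=O)COc1cccc2cccnc12)c1ccccc1`, gives > 100000 nM in an ADME assay on MCF7 cells (Homo sapiens) for cytotoxicity, read by MTT assay, with a stated time of 48 h; a higher number here means a weaker inhibitor, a lower number a stronger inhibitor.
compound 2, `C/C(=N\NC(=O)COc1cccc2cccnc12)c1ccc(Cl)cc1`, gives > 100000 nM in this assay.
compound 3, `c1ccc(-c2c[se]nn2)cc1`, has "not determined" (no result reported) in this assay.

The value of compound 1 is a limit of this assay, not a number. The value of compound 2 is likewise a limit, not a number. Among the compounds with values here, the one change between them, (chloro in place of hydrogen on an aromatic carbon), therefore gives a step that the two limits leave unreadable from compound 1 to compound 2. Both readings sit at the limit of > 100000 nM in this assay, at which 2 of the 3 values shown sit, so the step cannot be sized.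

Compound 3 is built on a different core; the difference between the two cores is not broken down here. For compound 3 no result was reported in this assay.

Compound 4, `Clc1ccc(-c2c[se]nn2)cc1`, still waits to be measured in this assay. It differs from compound 3 by chloro in place of hydrogen on an aromatic carbon. This is the same kind of change as that from compound 1 to compound 2, though the surroundings differ: in compound 2 the chloro stands para to a large group, in compound 4 para to a group of 5 heavy atoms.

Within the data shown here, since the only comparable step is unreadable and compound 3 has no value, compound 4 is estimated at 40000 nM, expected to fall between 8000 nM and 150000 nM, with a real chance that only a limit is reported.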

Compound 4, half-maximal inhibitory concentration: 57100 nM
Beside the measured number, compound 4's estimate is 1.4-fold (0.15 log units) below it; the measured number falls inside the stated range.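

No new step can be read from compound 4. Compound 3, which carries hydrogen where compound 4 carries chloro, has no reported result in this assay, leaving compound 4 at 57100 nM with no partner to compare against. From the compounds shown here alone, what chloro in place of hydrogen does on either core stays open, and the other pair offers limits rather than numbers: the limit of > 100000 nM in this assay, at which 2 of the 4 values shown sit.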